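Fluorinated stilbenes as nuclear factor reporter activators

This account rests on a few compounds, and the source may have more. Where it says the series, first, only, none or still open, it means among the compounds named here.

Measured so far:
compound 1 `Fc1cccc(F)c1/C=C/c1ccccc1` gives 6900 nM
compound 2 `Fc1cccc(/C=C/c2ccc(F)c(F)c2)c1` gives 5000 nM
compound 3 `Fc1ccccc1/C=C/c1c(F)cccc1F` gives 1400 nM

All three were run in an assay on HepG2 cells for activation of nuclear factor erythroid 2-related factor 2 (Homo sapiens), read by a luciferase reporter, with a stated time of 5 h; a higher number here means that more compound is needed for the effect, a lower number that less compound is needed. Compound 3 and compound 1 differ in one place, (hydrogen in place of fluoro on an aromatic carbon), and that change produced a step of a 4.9-fold higher number from compound 3 to compound 1 (0.69 log units; beyond the scatter). Compound 2 has the same atoms as compound 3 joined differently; the difference between the two cores is not broken down here. Compound 2 stands close to compound 1, within the scatter, while its gap to compound 3 lies beyond it.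

Compound 4 `Fc1ccc(/C=C/c2cccc(F)c2)cc1` has not been measured. It differs from compound 2 by hydrogen in place of fluoro on an aromatic carbon. This is the same kind of change as that from compound 3 to compound 1, but the place is not the same: there the fluoro that leaves is ortho to a large group, here it is ortho to a fluoro group and meta to a group of 9 heavy atoms. In this assay, among the measured compounds shown here, the step from compound 2 to compound 4 is expected to be a 2.0-fold higher number from compound 2 to compound 4 (0.30 log units; within the scatter), resting on the single measured instance a 4.9-fold higher number from compound 3 to compound 1 (0.69 log units; beyond the scatter) and tempered by the different surroundings. Compound 4 is therefore estimated at 10000 nM, expected between 4000 nM and 25000 nM.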

Compound 4, half-maximal effective concentration: 650 nM
Beside the measured number, compound 4's estimate is 15-fold (1.19 log units) above it; the whole stated range lies above it.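

In this assay, hydrogen in place of fluoro on an aromatic carbon gives a 7.7-fold lower number from compound 2 to compound 4 (0.89 log units; beyond the scatter), and the same change points the opposite way on the other core: the same change on two cores in this assay, a 4.9-fold higher number (0.69 log units; beyond the scatter) from compound 3 to compound 1 and a 7.7-fold lower number (0.89 log units; beyond the scatter) from compound 2 to compound 4, 38-fold (1.58 log units) apart, beyond the scatter of two such steps. This shows that neither the direction nor the size of the step carried from one core to the other in this pair, so a step measured on one core is a poor guide to the same change on another in this series. It does not show what sets the direction, since the core and the place of the change both differ between the two steps, and two steps give no general rule.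

The compounds shown carry only fluoro and hydrogen on their aromatic rings, so it remains open whether a chloro group, a methoxy group, a hydroxyl group or an amine at these places would depend on the core in the same way. Going by these compounds, it also remains open whether this change would repeat its direction at a fixed place across further cores.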